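Methyl for cyclohexyl on the sulfonyl of a cytotoxic series

A few compounds are considered here, and "the series" means these few. Any claim that something is new, unique, unknown or untested is made for them only; others in the source may bear on it.

Measured compounds in a functional assay on HL-60 cells (Homo sapiens) for cytotoxicity, read by luminescence; a lower number here means a stronger inhibitor, a higher number a weaker inhibitor:
compound 1 `C=C(CC)C(=O)c1ccc(OCC(=O)NCCNS(=O)(=O)C2CCCCC2)c(Cl)c1Cl`, compound 1 gives 1340 nM
compound 2 `C=C(CC)C(=O)c1ccc(OCC(=O)NCCNS(C)(=O)=O)c(Cl)c1Cl`, compound 2 gives 940 nM
compound 3 `C=C(CC)C(=O)c1ccc(OCC(=O)NC2CCN(S(=O)(=O)C3CCCCC3)CC2)c(Cl)c1Cl`, compound 3 gives 2940 nM

Compound 3 stands highest of the three numbers. The difference between the core of compound 1 and the core of compound 3 is not broken down here.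

The change from compound 1 to compound 2 is methyl in place of cyclohexyl on a sulfonyl sulfur
It gave a 1.4-fold lower number from compound 1 to compound 2 (0.15 log units; within the scatter).

Compound 4 `C=C(CC)C(=O)c1ccc(OCC(=O)NC2CCN(S(C)(=O)=O)CC2)c(Cl)c1Cl` is not yet measured. The change from compound 3 to compound 4 is methyl in place of cyclohexyl on a sulfonyl sulfur
Around the place the two cases differ: in compound 1 the sulfonyl sulfur sits on a sulfonamide nitrogen, in compound 3 on a sulfonamide nitrogen in a ring, so this is the same kind of change, not the same one.

The expectation for compound 4 rests on compound 1 and compound 2, because a 1.4-fold lower number from compound 1 to compound 2 (0.15 log units; within the scatter) was a small step. A step of about a 1.3-fold lower number from compound 3 to compound 4 (0.13 log units; within the scatter) is expected. Compound 4 is estimated at 2200 nM in this assay, with a range from 1000 nM to 4800 nM.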

Compound 4, half-maximal inhibitory concentration: 3330 nM
Beside the measured number, compound 4's estimate is 1.5-fold (0.18 log units) below it; measured number inside the range.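

In this assay, methyl in place of cyclohexyl on the sulfonyl sulfur gave a 1.1-fold higher number from compound 3 to compound 4 (0.05 log units; within the scatter), so on the core of compound 3 this step is also small. The two cores agree on this change: the same change on two cores in this assay, a 1.4-fold lower number (0.15 log units; within the scatter) from compound 1 to compound 2 and a 1.1-fold higher number (0.05 log units; within the scatter) from compound 3 to compound 4, 1.6-fold (0.21 log units) apart, within the scatter of two such steps. The change therefore carries between these two cores with no step beyond the scatter in this assay, but the two steps fix no direction for it and show nothing about other cores or other assays.

Open, from the compounds shown here alone, is whether a larger difference appears with other groups on the sulfonyl sulfur, such as phenyl or a longer chain ending in a carboxylic acid or an amine. Also open, going by these compounds, is whether either core would respond the same way to those groups.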